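Naphthalen-1-yl on the Urea Nitrogen: Compound 4 Expected

This account rests on a few compounds, and the source may have more. Where it says the series, first, only, none or still open, it means among the compounds named here.

Measured so far:
Compound 1, `CCNc1cc(-c2ccc(NC(=O)Nc3cccc(Cl)c3)cc2C)ccn1`: 82.7%
Compound 2, `CCNc1cc(-c2ccc(NC(=O)Nc3c(C)cccc3C)cc2C)ccn1`: 42.1%
Compound 3, `CCNc1cc(-c2ccc(NC(=O)Nc3cccc(Cl)c3)cc2C(F)(F)F)ccn1`: 94.9%

In an assay on isolated protein for inhibition of serine/threonine-protein kinase PLK1 (Homo sapiens), read by radiometric assay and 33P incorporation, with a stated time of 40 min, tested at 20 uM, in the presence of a further agent that is not named here (on this read-out higher numbers stand for more inhibition at the one concentration tested (going by the name of the read-out) and lower numbers for less inhibition), compound 3 gives 94.9% and stands highest of the three numbers. Its nearest neighbour is compound 1, with a number 12.2 percentage points higher from compound 1 to compound 3 (beyond the scatter), and the furthest is compound 2, which gives 42.1%. Compound 4, `CCNc1cc(-c2ccc(NC(=O)Nc3cccc4ccccc34)cc2C(F)(F)F)ccn1`, has not yet been measured; it differs from compound 3 by naphthalen-1-yl in place of 3-chlorophenyl on an amide-type nitrogen.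

Among the compounds with values here, one measured step bears on this change: the exchange of the group on the amide-type nitrogen, where a number 40.6 percentage points lower from compound 1 to compound 2 (beyond the scatter). Within the data shown here, that step was large and downward, and it is the only example here of altering the aryl on that nitrogen, while the step from compound 1 to compound 3 concerns another part of the shared core. Among the measured compounds shown here, because the one known change at the amide-type nitrogen showed a number 40.6 percentage points lower from compound 1 to compound 2 (beyond the scatter), compound 4 is expected to fall below compound 3, though with wide uncertainty since naphthalen-1-yl is not the same group as 2,6-dimethylphenyl. The expected step is a number 29.9 percentage points lower from compound 3 to compound 4 (beyond the scatter). For compound 4 the estimate in this assay is 65%, with a range from 30% to 92%.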

Compound 4, a percentage reported as inhibition, at one concentration (the size of the read-out at that concentration, not a potency): 54.1%
Estimate against measurement, compound 4: 10.9 percentage points above; measured number inside the range.
By their numbers in this assay, from the lowest: compound 2; then compound 4; then compound 1; then compound 3.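

In this assay, the change at the amide-type nitrogen from 3-chlorophenyl to naphthalen-1-yl gives a number 40.8 percentage points lower from compound 3 to compound 4 (beyond the scatter), so this position now shows a second large downward step. The first, a number 40.6 percentage points lower from compound 1 to compound 2 (beyond the scatter), came with a methyl group on the core, whereas this one comes with a trifluoromethyl group there, so the drop at this nitrogen is not confined to one version of the core. In both pairs the compound carrying 3-chlorophenyl holds the higher number, and neither 2,6-dimethylphenyl nor naphthalen-1-yl goes against this, although two replacements on two different cores make only a narrow basis for a pattern.

Nothing given here explains why the number falls with either replacement at this nitrogen. Still open, going by these compounds, is how an unsubstituted phenyl, a 3-methoxyphenyl or a 3-fluorophenyl would read on the trifluoromethyl core, and whether naphthalen-1-yl would give a step of similar size on the methyl core.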